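The compounds below may be only part of what the source reports. "The series", "measured", "known", "first", "only" and "open" are said of these compounds alone.

For the measured compounds named here, compound 2 `C=CC(=O)Nc1cc2c(N3CCc4ccccc43)ncnc2cc1O[C@@H]1CCOC1` gives 2710 nM in a functional assay on PC-3 cells (Homo sapiens) for antiproliferative activity, read by MTT assay, with a stated time of 72 h (on this read-out higher numbers stand for weaker inhibition and lower numbers for stronger inhibition), the lowest of the two numbers measured so far. The nearest is compound 1 `C=CC(=O)Nc1cc2c(N3CCc4ccccc43)ncnc2cc1OC`, which gives 5940 nM in this assay. Going by the values given here, the one measured step, a 2.2-fold lower number from compound 1 to compound 2 (0.34 log units; beyond the scatter), changes a group on an oxygen on an aromatic ring. Compound 3 `CC/C=C/C(=O)Nc1cc2c(N3CCc4ccccc43)ncnc2cc1O[C@@H]1CCOC1` differs from compound 2 at a different place: but-1-en-1-yl in place of vinyl on a carbonyl carbon. Among the compounds with values here, no measured step touches this carbonyl carbon, so the change from compound 2 to compound 3 in this assay is expected to stay within the scatter a 1.5-fold higher number from compound 2 to compound 3 (0.17 log units; within the scatter). Compound 3 is therefore estimated at 4000 nM, within 1500 nM to 12000 nM.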

Compound 3, half-maximal inhibitory concentration: 9590 nM
Beside the measured number, compound 3's estimate is 2.4-fold (0.38 log units) below it; low and high end bracket the measured number.
By their numbers in this assay, from the lowest: compound 2; then compounds 1 and 3 (each within the scatter of the next).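

In this assay, but-1-en-1-yl in place of vinyl on the carbonyl carbon gives a 3.5-fold higher number from compound 2 to compound 3 (0.55 log units; beyond the scatter). For the compounds shown here, this is the first sign that this position matters as well as the group on the oxygen: here, the longer chain goes with weaker inhibition. No supporting data explain this shift. Going by these compounds, with only these two groups compared on the carbonyl carbon, it remains open whether chain length alone tracks with the loss. On these data alone, it is also open how an amine carried on that chain would read in this assay.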